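Swapping the Acid Chain on a Fluorinated Core

A few compounds are considered here, and "the series" means these few. Any claim that something is new, unique, unknown or untested is made for them only; others in the source may bear on it.

Compound 1 `O=C(O)COCCCCC1=CCC[C@@H]1NS(=O)(=O)c1ccc(Cl)c(Cl)c1` gives 1900 nM in a functional assay on a cell-free system (plasma) for inhibition of thromboxane A2 receptor (Homo sapiens), read by turbidimetry; a higher number here means a weaker inhibitor, a lower number a stronger inhibitor. Compound 3 `O=C(O)CC/C=C\CC1=CCC[C@@H]1NS(=O)(=O)c1ccc(Cl)c(Cl)c1` gives 1900 nM in this assay; the step of no change at the digits printed from compound 1 to compound 3 (within the scatter) follows the change (4-carboxybut-1-en-1-yl in place of 3-(carboxymethoxy)propyl on a saturated chain carbon bound to a double-bonded ring carbon). Compound 2 `Cc1ccc(S(=O)(=O)N[C@H]2CC[C@@H](F)[C@@H]2CCCCOCC(=O)O)cc1` gives 1800 nM in this assay; how its core differs from that of compound 1 is not broken down here.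

Compound 4 `Cc1ccc(S(=O)(=O)N[C@H]2CC[C@@H](F)[C@@H]2C/C=C\CCC(=O)O)cc1` has not been measured. It differs from compound 2 by 4-carboxybut-1-en-1-yl in place of 3-(carboxymethoxy)propyl on a saturated chain carbon bound to a saturated ring carbon. This is the same kind of change as from compound 1 to compound 3, though here the chain sits on a saturated chain carbon bound to a saturated ring carbon rather than to a double-bonded ring carbon. Because no change at the digits printed from compound 1 to compound 3 (within the scatter) stayed flat, the step of no change at the digits printed from compound 2 to compound 4 (within the scatter) is expected to be small as well. Compound 4 is therefore estimated at 1800 nM in this assay, likely between 900 nM and 3600 nM.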

Compound 4, half-maximal inhibitory concentration: 1900 nM
The estimate for compound 4 lay 1.1-fold (0.02 log units) below the measured number, within the range that was stated.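

In this assay, putting 4-carboxybut-1-en-1-yl in place of 3-(carboxymethoxy)propyl gives a 1.1-fold higher number from compound 2 to compound 4 (0.02 log units; within the scatter), so the two chains cannot be told apart on this core. The same holds on the earlier core, and the change carries over between the two: the same change on two cores in this assay, no change at the digits printed (within the scatter) from compound 1 to compound 3 and a 1.1-fold higher number (0.02 log units; within the scatter) from compound 2 to compound 4, 1.1-fold (0.02 log units) apart, within the scatter of two such steps. Among these compounds, this shows agreement on only two cores, both with numbers of similar size, and does not show that the swap would be as silent on other cores or in other assays.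

The compounds shown leave open how a longer chain would behave on either core. They also leave open whether a tetrazole could stand in for the carboxylic acid.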